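Replacing the Imidazole Arm with a Pyrrolidine Arm

A few compounds are considered here, and "the series" means these few. Any claim that something is new, unique, unknown or untested is made for them only; others in the source may bear on it.

Compound 2 `Cc1cc(NCc2nccn2C)n2nc(C)c(-c3ccccc3)c2n1` carries a methyl-imidazolylmethylamino arm on its shared core. For the measured compounds named here, in a physicochemical assay for solubility, read by HPLC, using the shake flask method, measured as kinetic solubility, with a stated time of 2 h, at pH 7.4 (a lower number here means a less soluble compound, a higher number a more soluble compound), compound 2 gives 26900 nM, the highest of the two numbers measured so far. Going by the values given here, its only neighbour, compound 1 `Cc1cc(OCc2ccccn2)n2nc(C)c(-c3ccccc3)c2n1`, gives 25600 nM in this assay, and the step of a 1.1-fold higher number from compound 1 to compound 2 (0.02 log units; within the scatter) lies within the scatter, so the two cannot be ranked against each other.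

Compound 3 `CCN1CCCC1CNc1cc(C)nc2c(-c3ccccc3)c(C)nn12` has not yet been measured in this assay. It differs from compound 2 in one place: 1-ethylpyrrolidin-2-yl in place of 1-methyl-1H-imidazol-2-yl on a saturated chain carbon bound to a nitrogen on an aromatic ring. Among the compounds with values here, no measured step covers this particular exchange. Within the data shown here, the single step on record, a 1.1-fold higher number from compound 1 to compound 2 (0.02 log units; within the scatter), changed both the linking atom and the ring on the arm without moving the number beyond the scatter, which suggests that this arm tolerates changes without a large shift in this assay. The step from compound 2 to compound 3 is therefore expected to be a 1.1-fold higher number from compound 2 to compound 3 (0.05 log units; within the scatter), not beyond the scatter. For compound 3 the expected value in this assay is 30000 nM, with a range from 12000 nM to 75000 nM.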

Compound 3, solubility: 172000 nM
Estimate against measurement, compound 3: 5.7-fold (0.76 log units) below, outside the stated range (above it).
By their numbers in this assay, from the lowest: compounds 1 and 2 (each within the scatter of the next); then compound 3.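

In this assay, for the compounds shown here, this arm proves far less tolerant of change than compounds 1 and 2 implied: 1-ethylpyrrolidin-2-yl in place of 1-methyl-1H-imidazol-2-yl on a saturated chain carbon bound to a nitrogen on an aromatic ring gives a 6.4-fold higher number from compound 2 to compound 3 (0.81 log units; beyond the scatter) and is the first step beyond the scatter. The exchange swaps a five-membered aromatic ring with 2 hetero atoms for a five-membered non-aromatic ring with 1 hetero atom, and it also replaces the methyl on the ring with an ethyl, so this one step bundles several differences and cannot separate them. Nothing available here accounts for the higher number.

A 1-methylpyrrolidin-2-yl group would show whether the ethyl matters or whether the saturated ring alone carries the step. An open-chain amine, such as a diethylamino group on the same saturated chain, would leave open whether any ring is needed at this position at all.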